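This account rests on a few compounds, and the source may have more. Where it says the series, first, only, none or still open, it means among the compounds named here.

Measured so far in an ADME assay on cells (Hepatocyte, Homo sapiens) for metabolic stability, read by LC-MS, with a stated time of 60 min, tested at 1 uM; a lower number here means slower removal, a higher number faster removal of the compound:
compound 1 `COc1cc(N(CC2CC2)c2ccc(Cl)c(Cl)c2)cnc1C(=O)[C@H]1C[C@@H]1C(=O)O` gives 4.3 uL/min
compound 2 `COc1cc(N(CC2CC2)c2ccc(F)c3ccccc23)cnc1C(=O)[C@H]1C[C@@H]1C(=O)O` gives 5.4 uL/min
compound 3 `COc1cc(N(CC(C)C)c2ccc(F)c3ccccc23)cnc1C(=O)[C@H]1C[C@@H]1C(=O)O` gives 56 uL/min

Compound 3 stands highest of the three numbers in this assay; its nearest neighbour is compound 2, at a lower number beyond the scatter, and compound 1 lies further off still. Among the compounds with values here, the only step measured within a single change is a 10-fold higher number from compound 2 to compound 3 (1.02 log units; beyond the scatter), which puts the isobutyl chain well apart from the cyclopropylmethyl chain.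

Compound 4 `CCCN(c1cnc(C(=O)[C@H]2C[C@@H]2C(=O)O)c(OC)c1)c1ccc(F)c2ccccc12` is not yet measured. It differs from compound 3 by hydrogen in place of methyl on a saturated chain carbon bound to two saturated chain carbons; read one bond further out, isobutyl becomes propyl. Within the data shown here, no measured pair shows this exact change, so the only bearing comes from a 10-fold higher number from compound 2 to compound 3 (1.02 log units; beyond the scatter), where the chain on that nitrogen moved the number by a large step. Shortening the chain by one carbon is expected to pull the number back part of the way toward compound 2, though the direction is not secured by a directly comparable pair, and the expected step of a 1.6-fold lower number from compound 3 to compound 4 (0.20 log units; within the scatter) is kept modest with a wide range. Compound 4 is estimated at 35 uL/min in this assay, within 12 uL/min to 90 uL/min.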

Compound 4, intrinsic clearance in a liver preparation (reported as CLH), per the amount of preparation that the assay uses in the Hepatocyte assay: 7.6 uL/min
Estimate against measurement, compound 4: 4.6-fold (0.66 log units) above; the whole stated range lies above it.
By their numbers in the Hepatocyte assay, from the lowest: compounds 1, 2 and 4 (each within the scatter of the next); then compound 3.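

In the Hepatocyte assay, taking the methyl off the isobutyl chain gives a 7.4-fold lower number from compound 3 to compound 4 (0.87 log units; beyond the scatter), while the other comparison, a 1.4-fold higher number from compound 2 to compound 4 (0.15 log units; within the scatter), does not separate the propyl chain from the cyclopropylmethyl chain, so among these three compounds only the branched isobutyl chain stands apart, and a single methyl at this carbon is enough to set it apart. In a physicochemical assay for lipophilicity, read by LC-MS, in phosphate buffer, measured as octanol-water partition, at pH 7.4 (a higher number here means a more lipophilic compound, a lower number a more polar compound), compound 3 gives 2.2 and compound 4 gives 1.8, so this change moves both read-outs, and a number 0.40 log units lower from compound 3 to compound 4 (beyond the scatter) is a step beyond the scatter. The faster removal of compound 3 may be due in part to its higher lipophilicity, although a single pair cannot separate that from the branching itself: the measured distribution coefficient of compound 3, 2.2, and of compound 4, 1.8, a number 0.40 log units lower (beyond the scatter)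

From the compounds shown here alone, whether a longer chain such as butyl, or a chain carrying a hydroxyl group, would stay level with compound 2 and compound 4 or move toward compound 3 remains open. Also open, going by these compounds, is whether the number in the Hepatocyte assay follows the distribution coefficient beyond this one pair, and whether the same methyl has a comparable effect on the core of compound 1.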